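The compounds below may be only part of what the source reports. "The series", "measured", "known", "first", "only" and "open" are said of these compounds alone.

Measured so far:
- compound 1 `Cc1cccc(Cl)c1CN1CCc2cc(-c3c(C)nc(C)c([C@H](OC(C)(C)C)C(=O)O)c3N3CCC(C)(C)CC3)ccc2C1`: 35%
- compound 2 `Cc1nc(C)c([C@H](OC(C)(C)C)C(=O)O)c(N2CCC(C)(C)CC2)c1-c1ccc2c(c1)CCN(Cc1cccc(F)c1F)C2`: 50%

Within the data shown here, in an ADME assay on the whole organism (Rattus norvegicus, strain Sprague-Dawley) for pharmacokinetics, read by LC-MS, at a dose of 5 mg/kg by the oral route (a lower number here means that a smaller share of the oral dose reaches the circulation, a higher number that a larger share of the oral dose reaches the circulation), compound 2 gives 50%, the higher of the two numbers so far. Among the measured compounds shown here, its only neighbour, compound 1, gives 35%.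

Compound 3 `Cc1nc(C)c([C@H](OC(C)(C)C)C(=O)O)c(N2CCC(C)(C)CC2)c1-c1ccc2c(c1)CCN(Cc1ccc(F)cc1F)C2` keeps the shared core and alters one group: 2,4-difluorophenyl in place of 2,3-difluorophenyl on a saturated chain carbon bound to an amine nitrogen in a ring. The group stays on a saturated chain carbon bound to an amine nitrogen in a ring, and the same atoms are simply joined differently.

For the measured compounds named here, only one measured step bears on this place: a number 15 percentage points higher from compound 1 to compound 2 (beyond the scatter), which is modest but beyond the scatter. That step exchanged different atoms, whereas this one does not, so no step beyond the scatter is expected. The expected change is a number 2 percentage points lower from compound 2 to compound 3 (within the scatter). Compound 3 is estimated at 48%, with an expected range of 32% to 64%.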

Compound 3, oral bioavailability: > 100%
Compound 3 gave a limit, no number; the forecaster's own chance of this, stated with the estimate: 2%; middle value at least 52 percentage points from the limit.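

Compound 3 reads > 100% in this assay, which is a limit of the assay and not a number: the limit of > 100% in this assay, at which 1 of the 3 values shown sits. Even so, 2,4-difluorophenyl in place of 2,3-difluorophenyl gives a number at least 50 percentage points higher from compound 2 to compound 3 (beyond the scatter), so this position on a saturated chain carbon bound to an amine nitrogen in a ring can respond strongly when the same atoms are only joined differently. Measured against the 2-chloro-6-methylphenyl group, the change is a number at least 65 percentage points higher from compound 1 to compound 3 (beyond the scatter), a large step where the earlier comparison showed only a modest one.

Going by these compounds, the true size of both new steps stays open. Also open, on these data alone, is how a pyridyl or cyclohexyl group at this place would compare with the 2,4-difluorophenyl group.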